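Methylsulfanyl for trifluoromethoxy at the limit of the series

The source may hold more compounds than are shown below. What is called first, only, known or untested is meant among the compounds shown, and "the series" means these compounds.

Measured in a functional assay on MCF7 cells (Homo sapiens) for antiproliferative activity, read by MTT assay, with a stated time of 72 h (on this read-out higher numbers stand for weaker inhibition and lower numbers for stronger inhibition), each entry a limit:
Compound 1 `COc1cc(-c2ncnn2-c2cccc(F)c2)cc(OC)c1OC` gives > 10000 nM as a limit
Compound 2 `COc1cc(-n2ncnc2-c2ccc(OC(F)(F)F)cc2)cc(OC)c1OC` gives > 10000 nM as a limit
Compound 3 `COc1cc(-c2ncnn2-c2cccc([N+](=O)[O-])c2)cc(OC)c1OC` gives > 10000 nM as a limit

Compound 2 stands only at a limit of > 10000 nM and no number places it. Among the compounds with values here, the series so far shows the limit of > 10000 nM in this assay, at which 3 of the 3 values shown sit, and nothing more. Compound 4 `COc1cc(-n2ncnc2-c2ccc(SC)cc2)cc(OC)c1OC` carries methylsulfanyl in place of trifluoromethoxy on an aromatic carbon, para to a large group (methylsulfanyl in place of trifluoromethoxy on an aromatic carbon). Within the data shown here, the only measured step is a step that the two limits leave unreadable from compound 1 to compound 3 with nitro in place of fluoro, so no size carries over. The estimated step of an at least 2.0-fold lower number from compound 2 to compound 4 (0.30 log units; that floor lies within the scatter) is a weak expectation, with any readable change possible only towards stronger inhibition. In this assay the estimate for compound 4 is 5000 nM within an expected range from 50 nM to 15000 nM and may again be only a limit.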

Compound 4, half-maximal inhibitory concentration: 390 nM
For compound 4 the middle estimate is 13-fold (1.11 log units) above the measured one, and the stated range covers the measured number.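

Methylsulfanyl in place of trifluoromethoxy, on an aromatic carbon para to a large group, gives an at least 25-fold lower number from compound 2 to compound 4 (1.40 log units; beyond the scatter) in this assay. Within the data shown here, this is the first readable step, and it shows that activity can be reached on this core through a change at this position alone. Compound 4 is the only compound shown that leaves the shared limit: the limit of > 10000 nM in this assay, at which 3 of the 4 values shown sit.

From the compounds shown here alone, whether a methoxy group, an amine or a longer thioether chain at this position would do the same stays open. Going by these compounds, whether methylsulfanyl would have the same effect on the core of compound 1 also stays open.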